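Series notes: fluoro to cyano on the benzyl group

The source may report more compounds than this note shows. Statements on the series, on what has been measured and on what is new or still open speak of the compounds shown alone.

Three compounds of the series have numbers in a functional assay on RAW264.7 cells (Mus musculus) for inhibition, read by Griess assay, with stated times of 2 h and 24 h; a lower number here means a stronger inhibitor, a higher number a weaker inhibitor. Compound 1 `COc1ccc([C@@H]2C/C(=N\O)c3c(O)cc(OCc4cn(CC5CC5)nn4)cc3O2)cc1O` gives 6320 nM; compound 3 `COc1ccc([C@@H]2C/C(=N\O)c3c(O)cc(OCc4cn(C5CCCC5)nn4)cc3O2)cc1O` gives 6880 nM; compound 2 `COc1ccc([C@@H]2CC(=O)c3c(O)cc(OCc4cn(Cc5ccccc5F)nn4)cc3O2)cc1O` gives 7320 nM. Compound 2 has the highest of the three numbers, but its gaps to compound 3 and to compound 1 are both within the scatter, so no order among the three can be read from them. Among the measured compounds shown here, the only single-point step available, a 1.1-fold higher number from compound 1 to compound 3 (0.04 log units; within the scatter), also lies within the scatter.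

Compound 4 `COc1ccc([C@@H]2CC(=O)c3c(O)cc(OCc4cn(Cc5ccccc5C#N)nn4)cc3O2)cc1O` differs from compound 2 in one place: cyano in place of fluoro on an aromatic carbon. Cut one bond further out, the change reads 2-fluorobenzyl to 2-cyanobenzyl. For the measured compounds named here, no measured step touches this part of the structure; the one step known, cyclopentyl in place of cyclopropylmethyl on an aromatic nitrogen, concerns a different part of the molecule and stayed within the scatter. Going by the values given here, the three values together show that the one change tried so far has not moved the number beyond the scatter, and nothing in the data argues for a larger effect from this change.

For compound 4 the expected step is a 1.0-fold lower number from compound 2 to compound 4 (0.02 log units; within the scatter), no change beyond the scatter in either direction. The estimate for compound 4 in this assay is 7000 nM, with a range from 3500 nM to 14000 nM.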

Compound 4, half-maximal inhibitory concentration: 14600 nM
The estimate for compound 4 lay 2.1-fold (0.32 log units) below the measured number, and the stated range ends below it.
By their numbers in this assay, from the lowest: compounds 1, 3, 2 and 4 (each within the scatter of the next, the first and the last beyond it).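

In this assay, among the compounds shown here, the only step read on the benzyl ring is 2-fluorobenzyl to 2-cyanobenzyl, which gives a 2.0-fold higher number from compound 2 to compound 4 (0.30 log units; within the scatter). This step stays within the scatter, so replacing fluoro with cyano on this aromatic carbon, and with it adding one heavy atom and one hydrogen-bond acceptor, cannot be said to change the number at this position, and neither a loss nor a gain can be assigned to the cyano group. The data on hand offer no measured basis for explaining the size of this step.

A single pair leaves open how this aromatic carbon responds to other groups, such as an amine, a carboxylic acid or a methoxy group, and whether the unsubstituted benzyl group would read any differently from the 2-fluorobenzyl and 2-cyanobenzyl groups. The carbonyl of compounds 2 and 4 and the oxime of compounds 1 and 3 also remain unresolved, as no pair shown differs in that place alone.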